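The source may hold more compounds than are shown below. What is called first, only, known or untested is meant among the compounds shown, and "the series" means these compounds.

Measured in an assay on membranes from HEK293 cells for displacement of a labelled ligand from adenosine receptor A2b (Homo sapiens), read by scintillation counting, with a stated time of 30 min, tested at 1 uM; a higher number here means more inhibition at the concentration tested (going by the name of the read-out), a lower number less inhibition:

compound 1, `CCCC(=O)C1=C(C)NC(=O)NC1c1cccs1`: 9%
compound 2, `CC1=C(C(=O)CC(C)C)C(c2cccs2)NC(=O)N1`: 43%
compound 3, `CCNC(=O)C1=C(C)NC(=O)NC1c1ccco1`: 1%

Compound 1 and compound 2 share a core and differ in one place: methyl in place of hydrogen on a saturated chain carbon bound to two saturated chain carbons. Among the compounds with values here, this single change gives a number 34 percentage points higher from compound 1 to compound 2 (beyond the scatter), the only clear step among the three measured compounds. Compound 3 differs from compound 1 in more than one place; the difference between the two cores is not broken down here. The values of compound 3 and compound 1 in this assay lie within the scatter of each other, while the gap from compound 3 to compound 2 lies beyond it.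

Compound 4, `CC1=C(C(=O)NC(C)C)C(c2ccco2)NC(=O)N1`, is not yet measured and differs from compound 3 in one place: methyl in place of hydrogen on a saturated chain carbon bound to an amide-type nitrogen and a saturated chain carbon. Within the data shown here, this is the same kind of change as the one from compound 1 to compound 2, not the same change: in compound 2 the methyl enters on a saturated chain carbon bound to two saturated chain carbons, in compound 4 on a saturated chain carbon bound to an amide-type nitrogen and a saturated chain carbon, and the two cores carrying the change also differ.

A rise is expected from compound 3 to compound 4, estimated at a number 14 percentage points higher from compound 3 to compound 4 (beyond the scatter). The estimated step is set smaller because a number 34 percentage points higher from compound 1 to compound 2 (beyond the scatter) was measured on a different core and at a carbon of a different kind, and because compound 3 starts from 1%. Compound 4 is expected to give about 15% in this assay, estimated between 0% and 40%.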

Compound 4, a percentage reported as inhibition, at one concentration (the size of the read-out at that concentration, not a potency): 2%
Compound 4: the middle estimate sits 13 percentage points above what was measured; measured number inside the range.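

In this assay, ethylcarbamoyl to isopropylcarbamoyl on the core of compound 3 gives a number 1 percentage points higher from compound 3 to compound 4 (within the scatter) and so leaves the two compounds within the scatter of each other, with no clear gain from the added methyl on the saturated chain carbon bound to an amide-type nitrogen and a saturated chain carbon. The size of the step therefore does not carry from one core to the other in this series, and the earlier result cannot be used as a transferable increment: the same change on two cores in this assay, a number 34 percentage points higher (beyond the scatter) from compound 1 to compound 2 and a number 1 percentage points higher (within the scatter) from compound 3 to compound 4, 33 percentage points apart, beyond the scatter of two such steps. Within the data shown here, this does not show which difference between the pairs matters, since the cores differ, the methyl sits on carbons of different kinds, and each core supplies only one pair, all read at a single concentration and thus without a potency.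

Open, from the compounds shown here alone, is whether a longer chain, or an amine or carboxylic acid at the end of the chain on the carbamoyl group, would take the core of compound 3 beyond the scatter of compound 3 itself. Also open, going by these compounds, is whether further pairs carrying the same methyl change would side with the large step or the small one.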